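Swapping the aryl group on the shared core

This account rests on a few compounds, and the source may have more. Where it says the series, first, only, none or still open, it means among the compounds named here.

Compound 2 `N#CC1=C(N)N(c2ccc(S(N)(=O)=O)cc2)C2=C(C(=O)CCC2)C1c1ccc(Cl)cc1Cl` and compound 1 `COc1cc(CC2C(C#N)=C(N)N(c3ccc(S(N)(=O)=O)cc3)C3=C2C(=O)CCC3)ccc1O` share one core and differ only in the group carried on a saturated ring carbon. In a functional assay on Ehrlich cells (Mus musculus) for antiproliferative activity, read by trypan blue exclusion, with a stated time of 2 h, tested at 25 ug/mL (a lower number here means a weaker effect, a higher number a stronger effect of the compound at the concentration tested), compound 1 gives 50%. In the same test compound 2 gives 50%, so compound 2 stands level with compound 1, and the step of no change at the digits printed from compound 1 to compound 2 (within the scatter) lies within the scatter of the assay.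

Compound 3 `N#CC1=C(N)N(c2ccc(S(N)(=O)=O)cc2)C2=C(C(=O)CCC2)C1c1c(O)ccc2ccccc12` is not yet measured. It differs from compound 2 in a single place: 2-hydroxynaphthalen-1-yl in place of 2,4-dichlorophenyl on a saturated ring carbon. Among the measured compounds shown here, the one measured step that bears on this change, no change at the digits printed from compound 1 to compound 2 (within the scatter), exchanged one aryl group for another on the same saturated ring carbon and did not move the read-out beyond the scatter. For the measured compounds named here, only one such step is known, and it involved other groups, so the expectation rests on thin evidence. Still, the expected step is no change at the digits printed from compound 2 to compound 3 (within the scatter), which means no change beyond the scatter. Compound 3 is therefore estimated at 50%, with a range from 30% to 70%.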

Compound 3, a percentage reported as activity, at one concentration (the size of the read-out at that concentration, not a potency): 0%
For compound 3 the middle estimate is 50 percentage points above the measured one, and the stated range ends above it.
By their numbers in this assay, from the lowest: compound 3; then compounds 1 and 2 (each within the scatter of the next).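

The group on this saturated ring carbon is not a free choice, although the earlier pair could have suggested so. In this assay the 2-hydroxynaphthalen-1-yl group gives a number 50 percentage points lower from compound 2 to compound 3 (beyond the scatter) when it replaces 2,4-dichlorophenyl and a number 50 percentage points lower from compound 1 to compound 3 (beyond the scatter) when it replaces 4-hydroxy-3-methoxybenzyl, so two quite different groups stand level while this third one removes the effect seen at the tested concentration. No measurement available here explains the loss, and the compounds show only that it goes with this exchange of groups.

The exchange alters several things at once: the two chlorine atoms leave, while a second six-membered aromatic ring of carbon and a hydroxyl group enter, and these compounds cannot separate the contributions of those parts. Plain naphthalen-1-yl and 2-hydroxyphenyl would pull apart the second ring and the hydroxyl group, a methoxy group in place of that hydroxyl group would test the hydroxyl hydrogen, and an aminomethyl or carboxylic acid substituent on the aryl ring would extend the comparison to quite different groups.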